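Swapping ethyl for hydrogen on compound 2

A few compounds are considered here, and "the series" means these few. Any claim that something is new, unique, unknown or untested is made for them only; others in the source may bear on it.

In a functional assay on T-24 cells (Homo sapiens) for cytotoxicity, read by colorimetric assay and MTT assay (a higher number here means a weaker inhibitor, a lower number a stronger inhibitor), compound 1 (`COc1cc(OC)c2cc(-c3ccc(OCc4ccccc4)cc3)c(O)nc2c1`) gives 10000 nM as its reading. Level with it, compound 2 (`CCOC(=O)Cn1c(=O)c(-c2ccc(OC)cc2)cc2c(OC)cc(OC)cc21`) gives 10000 nM as well. Compound 3 (`COc1ccc(-c2cc3c(OC)cc(OC)cc3n(CC(=O)O)c2=O)cc1`), not yet measured, differs from compound 2 in one place (hydrogen in place of ethyl on an oxygen next to a carbonyl group): hydrogen in place of ethyl on an oxygen next to a carbonyl group, so ethoxycarbonyl becomes carboxy. Going by the values given here, no measured pair shows what this change does. Starting from compound 2 at 10000 nM no shift beyond the scatter, in either direction, is expected in this assay here. The expected step (no change at the digits printed from compound 2 to compound 3 (within the scatter)) therefore stays small. The estimate for compound 3 is 10000 nM (expected range 4000 nM to 25000 nM).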

Compound 3, half-maximal inhibitory concentration: 10000 nM
Estimate against measurement, compound 3: no gap at the digits printed, and the stated range covers the measured number.
By their numbers in this assay, from the lowest: compounds 1, 2 and 3 (each within the scatter of the next).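

In this assay, putting hydrogen in place of ethyl on an oxygen next to a carbonyl group, which turns ethoxycarbonyl into carboxy, gives no change at the digits printed from compound 2 to compound 3 (within the scatter). This first measured pair at this position shows that this assay does not separate the (ethoxycarbonyl)methyl group from the carboxymethyl group. No measurement offered here explains this reading. On these data alone, whether an amide or a longer chain at this position would give a different reading remains open, and so does the effect of changes elsewhere on the shared core.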